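A Trifluoromethyl Step Repeated on a Second Core

The source may hold more compounds than are shown below. What is called first, only, known or untested is meant among the compounds shown, and "the series" means these compounds.

Measured in an ADME assay on HEK293 cells (Homo sapiens) for cytotoxicity, read by MTT assay, with a stated time of 48 h; a higher number here means a weaker inhibitor, a lower number a stronger inhibitor:
compound 1, `Cc1cc(NC(=O)c2cccc(C(F)(F)F)c2)ccc1NS(=O)(=O)C(F)(F)F`, gives 131000 nM.
compound 2, `Cc1cc(NC(=O)c2cc(C(F)(F)F)cc(C(F)(F)F)c2)ccc1NS(=O)(=O)C(F)(F)F`, gives 182000 nM.
compound 3, `CCS(=O)(=O)Nc1ccc(NC(=O)c2cccc(C(F)(F)F)c2)cc1OC`, gives > 250000 nM, which is a limit of this assay and not a number.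

Compound 4, `CCS(=O)(=O)Nc1ccc(NC(=O)c2cc(C(F)(F)F)cc(C(F)(F)F)c2)cc1OC`, has not yet been measured. Compound 4 stands to compound 3 as compound 2 stands to compound 1: trifluoromethyl in place of hydrogen on an aromatic carbon and trifluoromethyl in place of hydrogen on an aromatic carbon describe the same change, with the same surroundings. The difference between the cores of compound 1 and compound 3 is not broken down here. On the first core the step was a 1.4-fold higher number from compound 1 to compound 2 (0.14 log units; within the scatter). Because compound 3 already sits at the limit of > 250000 nM in this assay, at which 1 of the 3 values shown sits, the same change on its core is expected to leave compound 4 at that limit as well, with an expected step that the limit leaves unreadable from compound 3 to compound 4. Compound 4 is therefore estimated at 350000 nM, between 250000 nM and 600000 nM.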

Compound 4, half-maximal inhibitory concentration: > 250000 nM
Compound 4 ended at the assay's limit; the forecaster's own chance of this, stated with the estimate: 85%; the middle value lies beyond the limit too.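

In this assay, among the compounds shown here, no step from compound 3 to compound 4 can be read, since both compounds stand at a limit of the assay and not at a number: the limit of > 250000 nM in this assay, at which 2 of the 4 values shown sit. The compounds shown leave open whether the trifluoromethyl step on this core matches the one on the core of compound 1.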